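Working notes: the step from compound 2 to compound 3

The source may hold more compounds than are shown below. What is called first, only, known or untested is meant among the compounds shown, and "the series" means these compounds.

Measured in a functional assay on HT-29 cells (Homo sapiens) for antiproliferative activity, read by MTT assay, with a stated time of 24 h; a higher number here means a weaker inhibitor, a lower number a stronger inhibitor:
- compound 1 `COc1ccc(C(=O)/C=C/c2ccc([N+](=O)[O-])cc2)c2c1C=CC(C)(C)O2`: 3730 nM
- compound 2 `COc1ccc(C(=O)/C=C/c2cccc([N+](=O)[O-])c2)c2c1C=CC(C)(C)O2`: 4260 nM

Going by the values given here, compound 2 sits within the scatter of compound 1, the only other measured compound. Among the compounds with values here, the single measured step is a 1.1-fold higher number from compound 1 to compound 2 (0.06 log units; within the scatter). Compound 3 `COc1ccc(/C=C/C(=O)c2ccc(OC)c3c2OC(C)(C)C=C3)cn1` changes the same place: 6-methoxypyridin-3-yl in place of 3-nitrophenyl on a double-bonded chain carbon bound to a double-bonded chain carbon. The measured step only exchanges 4-nitrophenyl for 3-nitrophenyl, so no measured case covers 6-methoxypyridin-3-yl, and the uncertainty is wide. With compound 2 at 4260 nM as the anchor, no step beyond the scatter is expected in this assay. The expected step is a 1.1-fold lower number from compound 2 to compound 3 (0.03 log units; within the scatter). Compound 3 is estimated at 4000 nM, with an expected range of 1600 nM to 11000 nM.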

Compound 3, half-maximal inhibitory concentration: > 10000 nM
Compound 3: only a limit was reported; the forecaster's own chance of this, stated with the estimate: 5%; middle value at least 2.5-fold (0.39 log units) from the limit.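

In this assay, the group on this chain carbon does matter: 4-nitrophenyl and 3-nitrophenyl stay within the scatter of each other, whereas 6-methoxypyridin-3-yl gives an at least 2.3-fold higher number from compound 2 to compound 3 (0.37 log units; beyond the scatter) and an at least 2.6-fold higher number from compound 1 to compound 3 (0.42 log units; beyond the scatter). Compound 3 carries only a limit, not a number, so the full size of both steps stays unknown: the limit of > 10000 nM in this assay, at which 1 of the 3 values shown sits.

The ring nitrogen and the methoxy group enter together, and the compounds shown do not separate them. Going by these compounds, how a plain phenyl, a 4-methoxyphenyl or a 4-aminophenyl would read at this place remains open.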